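A larger side chain on compound 2

A few compounds are considered here, and "the series" means these few. Any claim that something is new, unique, unknown or untested is made for them only; others in the source may bear on it.

- Compound 1 `O=C1c2c[n+]([O-])c3ccccc3c2C(=O)c2c1c1ccccc1n2CCCCn1ccnc1` gives 150 nM
- Compound 2 `O=C1c2c[n+]([O-])c3ccccc3c2C(=O)c2c1c1ccccc1n2CCN1CCCC1` gives 930 nM

In a toxicity assay on L02 cells (Homo sapiens) for cytotoxicity, read by MTT assay, with a stated time of 72 h (a lower number here means a stronger inhibitor, a higher number a weaker inhibitor), compound 1 stands at the lower number (150 nM) and compound 2 at the higher one (930 nM). Compound 3 `CCCCN1CCN(CCCCn2c3c(c4ccccc42)C(=O)c2c[n+]([O-])c4ccccc4c2C3=O)CC1` keeps the shared core of compound 2 and differs in one place (2-(4-butylpiperazin-1-yl)ethyl in place of pyrrolidin-1-yl on a saturated chain carbon, two bonds along the chain from an aromatic nitrogen). Among the compounds with values here, only one measured step bears on this change, and it is modest: a 6.2-fold higher number from compound 1 to compound 2 (0.79 log units; beyond the scatter) in the swap of 2-(1H-imidazol-1-yl)ethyl for pyrrolidin-1-yl. Going by that step alone, where the larger group of compound 1 sits with the lower number, a move of similar or smaller size toward a lower number is expected in this assay for the new group. A single step sets no rule, so the direction remains uncertain. The expected change is a 2.3-fold lower number from compound 2 to compound 3 (0.37 log units; beyond the scatter) as estimated here. The estimated value for compound 3 is 400 nM (range 120 nM to 1300 nM).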

Compound 3, half-maximal inhibitory concentration: 5690 nM
Compound 3: the middle estimate sits 14-fold (1.15 log units) below what was measured; measured number above the stated range.
By their numbers in this assay, from the lowest: compound 1; then compound 2; then compound 3.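

In this assay, 2-(4-butylpiperazin-1-yl)ethyl in place of pyrrolidin-1-yl gives a 6.1-fold higher number from compound 2 to compound 3 (0.79 log units; beyond the scatter), so at this place a larger group does not by itself bring a lower number. The opposite rule fails too, since compound 1 also carries a group larger than pyrrolidin-1-yl yet has the lowest number of the three, so size alone does not order these compounds. The gap between the two end groups on the longer chain is wider still: 4-butylpiperazin-1-yl in place of 1H-imidazol-1-yl gives a 38-fold higher number from compound 1 to compound 3 (1.58 log units; beyond the scatter).

No measured reason for these differences is available. Going by these compounds, it remains open whether the butyl group or the piperazine ring drives the rise, which a 4-methylpiperazin-1-yl or plain piperazin-1-yl group on the same chain could help separate.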